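From Carbamoyl to (Isopropoxycarbonyl)amino: Expecting Compound 4

The compounds below may be only part of what the source reports. "The series", "measured", "known", "first", "only" and "open" are said of these compounds alone.

Compound 2 `Cc1cc(C(N)=O)nn1Cc1cc(Cl)ccc1OCC(C)C` gives 126 nM in an assay on CHO-K1 cells for displacement of a labelled ligand from prostaglandin E2 receptor EP1 subtype (Homo sapiens) (on this read-out lower numbers stand for stronger inhibition and higher numbers for weaker inhibition), level at the digits shown with compound 1 `Cc1cc(C(N)=O)nn1Cc1cc(Cl)ccc1OCc1ccccc1`, which gives 126 nM; together these two are the highest of the three numbers. Compound 3 `Cc1cc(NC(=O)c2ccccc2)nn1Cc1cc(Cl)ccc1OCc1ccccc1` gives 15.9 nM and stands furthest from compound 2. Compound 4 `Cc1cc(NC(=O)OC(C)C)nn1Cc1cc(Cl)ccc1OCC(C)C` differs from compound 2 by (isopropoxycarbonyl)amino in place of carbamoyl on an aromatic carbon. Among the measured compounds shown here, two measured steps bear on this change. The step of no change at the digits printed from compound 1 to compound 2 (within the scatter) shows no difference between the benzyl ether and the isobutyl ether, so compound 2 is a fair starting point for the carbamoyl replacement. The step of a 7.9-fold lower number from compound 1 to compound 3 (0.90 log units; beyond the scatter) shows that putting an acylamino group in place of carbamoyl on the same aromatic carbon gave a modestly lower number. The group entering compound 4 is of that same kind, carrying isopropoxy rather than phenyl on the carbonyl, so a modest drop is expected, about the size of that step or somewhat less. Compound 4 is therefore estimated at 32 nM, with a range from 10 nM to 100 nM. This corresponds to an expected step of a 3.9-fold lower number from compound 2 to compound 4 (0.60 log units; beyond the scatter).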

Compound 4, half-maximal inhibitory concentration: 50.1 nM
The estimate for compound 4 lay 1.6-fold (0.19 log units) below the measured number, within the range that was stated.
By their numbers in this assay, from the lowest: compound 3; then compound 4; then compounds 1 and 2 (each within the scatter of the next).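

In this assay the step of a 2.5-fold lower number from compound 2 to compound 4 (0.40 log units; beyond the scatter) shows that the lower number at this aromatic carbon is not confined to benzamido on the benzyl ether. The earlier step of a 7.9-fold lower number from compound 1 to compound 3 (0.90 log units; beyond the scatter) offered only that one case, whereas the new step goes the same way with (isopropoxycarbonyl)amino, carrying isopropoxy rather than phenyl on the carbonyl, on the isobutyl ether. No measurement at hand accounts for the drop.

From the compounds shown here alone, compound 3 and compound 4 differ in two places, so how benzamido and (isopropoxycarbonyl)amino rank on one and the same ether stays open. Also open, going by these compounds, is what a plain amine or an acetamido group on this carbon would give, and thus whether the carbonyl of the entering group matters at all.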